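Replacing 2-aminophenyl with hydroxy on an amide-type nitrogen

This account rests on a few compounds, and the source may have more. Where it says the series, first, only, none or still open, it means among the compounds named here.

For the measured compounds named here, in a functional assay on HCT-116 cells (Homo sapiens) for inhibition, read by MTT assay, with a stated time of 72 h (a lower number here means a stronger inhibitor, a higher number a weaker inhibitor), compound 1 (`Nc1ccccc1NC(=O)c1ccc(CNCc2nc(-c3ccc(F)cc3)no2)cc1`) gives 3510 nM as the lower of the two numbers known so far. Compound 2 (`O=C(NO)c1ccc(CNCc2nc(-c3ccc(Cl)cc3)no2)cc1`) gives 30200 nM in the same test, a gap beyond the usual scatter. Compound 3 (`O=C(NO)c1ccc(CNCc2nc(-c3ccc(F)cc3)no2)cc1`) has not yet been measured. It differs from compound 1 by one change, hydroxy in place of 2-aminophenyl on an amide-type nitrogen. Going by the values given here, no measured pair shows this change alone, so the best guide is compound 2, which also carries hydroxy on that nitrogen and gives 30200 nM as its result. The expected change is a 5.7-fold higher number from compound 1 to compound 3 (0.76 log units; beyond the scatter) in this assay, a move beyond the scatter towards a weaker inhibitor. The estimate for compound 3 is 20000 nM with an expected range from 7000 nM to 60000 nM in this test.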

Compound 3, half-maximal inhibitory concentration: 17800 nM
The estimate for compound 3 lay 1.1-fold (0.05 log units) above the measured number; the measured number falls inside the stated range.
By their numbers in this assay, from the lowest: compound 1; then compounds 3 and 2 (each within the scatter of the next).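

In this assay, for the compounds shown here, this is the first direct reading of the change on the amide-type nitrogen: with the fluoro group held fixed, hydroxy in place of 2-aminophenyl gives a 5.1-fold higher number from compound 1 to compound 3 (0.71 log units; beyond the scatter) and so a modest move towards a weaker inhibitor. The second pair, with a 1.7-fold lower number from compound 2 to compound 3 (0.23 log units; within the scatter) for fluoro in place of chloro on an aromatic carbon, shows that these two halogens cannot be told apart in this test. Together, the two pairs tie the earlier gap between compound 1 and compound 2 to the group on the nitrogen rather than to the halogen.

A plain phenyl or a methyl on that nitrogen would show whether the amino group of 2-aminophenyl matters or whether the ring alone is enough. Nothing available here explains why the group on this nitrogen shifts the number.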